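The compounds below may be only part of what the source reports. "The series", "measured", "known", "first", "only" and "open" are said of these compounds alone.

For the measured compounds named here, in a functional assay on the whole organism with Scenedesmus acutus as the target, with a stated time of 20 h (a lower number here means a stronger inhibitor, a higher number a weaker inhibitor), compound 2 `CCC(C)OC(=O)c1cc(N2C(=O)C3=C(CCCC3)C2=O)c(F)cc1Cl` gives 74.1 nM, the lower of the two numbers measured so far, while compound 1 `O=C(O)c1cc(N2C(=O)C3=C(CCCC3)C2=O)c(F)cc1Cl` gives 3160 nM. Compound 3 `C#CCOc1cc(N2C(=O)C3=C(CCCC3)C2=O)c(F)cc1Cl` carries propargyloxy in place of sec-butoxycarbonyl on an aromatic carbon. Going by the values given here, the one measured step, a 43-fold lower number from compound 1 to compound 2 (1.63 log units; beyond the scatter), was large, but it exchanges only the hydrogen for sec-butyl on the same carboxyl oxygen. Among the compounds with values here, it therefore bears only indirectly, and no measured compound carries propargyloxy. Only a small step with an uncertain direction is expected, estimated as a 1.5-fold lower number from compound 2 to compound 3 (0.17 log units; within the scatter). Compound 3 is estimated at 50 nM, with an expected range of 10 nM to 250 nM.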

Compound 3, half-maximal inhibitory concentration: 141 nM
Estimate against measurement, compound 3: 2.8-fold (0.45 log units) below; measured number inside the range.
By their numbers in this assay, from the lowest: compounds 2 and 3 (each within the scatter of the next); then compound 1.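

In this assay the aromatic carbon ortho to the chloro group and para to the fluoro group accepts propargyloxy as well as sec-butoxycarbonyl, with a 1.9-fold higher number from compound 2 to compound 3 (0.28 log units; within the scatter) as the step between them. Propargyloxy in place of carboxy gives a 22-fold lower number from compound 1 to compound 3 (1.35 log units; beyond the scatter) and so shows that a large step away from the acid does not require an ester carbonyl at this position. Nothing available explains these steps. Still open, on these data alone, is how a methoxy group, an amine or a longer chain ending in a triple bond would compare at this carbon.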